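From 4-Fluorophenyl to Thiophen-2-yl on a Shared Core

A few compounds are considered here, and "the series" means these few. Any claim that something is new, unique, unknown or untested is made for them only; others in the source may bear on it.

Measured so far:
compound 1 `Cc1cc(NC(=O)Cn2cc(-c3ccc(F)cc3)nn2)no1` gives > 30000 nM
compound 2 `COC(=O)c1ccc(-c2cn(CC(=O)Nc3cc(C)on3)nn2)cc1` gives > 30000 nM

Of the compounds shown here, two have been tested in a functional assay on BMDM cells (Mus musculus, strain C57BL/6) for inhibition, with a stated time of 2 days; a higher number here means a weaker inhibitor, a lower number a stronger inhibitor. Compound 1 stands at the limit of the assay, and its value > 30000 nM is a limit rather than a number. Compound 2 likewise returns > 30000 nM, again a limit and not a number. Within the data shown here, the single measured step, a step that the two limits leave unreadable from compound 1 to compound 2, cannot be read because of the limit of > 30000 nM in this assay, at which 2 of the 2 values shown sit.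

Compound 3 `Cc1cc(NC(=O)Cn2cc(-c3cccs3)nn2)no1` is not yet measured. It differs from compound 1 by a single exchange: thiophen-2-yl in place of 4-fluorophenyl on an aromatic carbon. Among the measured compounds shown here, no measured step touches this exchange, and the one step that exists, from a fluoro to a methoxycarbonyl group, is itself unreadable, so nothing in the data points to a change in either direction.

Since compound 1 sits at the limit, compound 3 is expected to remain near that limit as well. The estimate for compound 3 is 40000 nM, with a range from 15000 nM to 100000 nM. The expected step is a step that the limit leaves unreadable from compound 1 to compound 3, which is not expected to exceed the usual scatter.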

Compound 3, half-maximal inhibitory concentration: > 30000 nM
Compound 3 was reported as a limit (the forecaster's own chance of this, stated with the estimate: 85%); the middle value lies beyond the limit too.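

In this assay compound 3 gives > 30000 nM, a limit and not a number. No step among compound 1, compound 2 and compound 3 can be read, because all their values rest on one limit: the limit of > 30000 nM in this assay, at which 3 of the 3 values shown sit.

The compounds shown leave open how strongly each one inhibits in this assay, and whether any group on the shared core would give a readable value.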